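The compounds below may be only part of what the source reports. "The series", "measured", "known", "first", "only" and "open" are said of these compounds alone.

In a functional assay on SK-OV-3 cells (Homo sapiens) for cytotoxicity, read by MTT assay, with a stated time of 24 h (a lower number here means a stronger inhibitor, a higher number a weaker inhibitor), compound 1 `C#CCn1c(=O)c(C=O)cc2cc(Cl)ccc21` gives only a limit of the assay, > 100000 nM. Compound 2 `C#CCn1c(=O)c(C=O)cc2cc(F)ccc21` likewise gives only a limit in this assay, namely > 100000 nM. The step from compound 1 to compound 2, fluoro in place of chloro on an aromatic carbon, is a step that the two limits leave unreadable from compound 1 to compound 2 because of the limit of > 100000 nM in this assay, at which 2 of the 2 values shown sit. Compound 2 therefore stands at that limit and at no number of its own.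

Compound 3 `C#CCn1c(=O)c(C=O)cc2cc(OC)ccc21` differs from compound 2 by methoxy in place of fluoro on an aromatic carbon. Within the data shown here, no measured step bears directly on this change, and the single step that is known offers no readable size. Among the measured compounds shown here, one therefore expects no step in this assay that could be told from the scatter, and the expected step is a number no higher from compound 2 to compound 3 (the limit leaves the size open). Compound 3 is accordingly estimated at 100000 nM in this assay, within a range from 30000 nM to 300000 nM.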

Compound 3, half-maximal inhibitory concentration: > 100000 nM
Compound 3: a limit, no number; the forecaster's own chance of this, stated with the estimate: 75%; the middle value sits exactly at the limit.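

Compound 3, like compound 1 and compound 2, yields no readable step, so none of the changes among these three compounds can be sized: the limit of > 100000 nM in this assay, at which 3 of the 3 values shown sit.

What the compounds shown leave open is how any of the three would rank in this assay, and whether any substituent at this place on the shared core changes the result.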